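The source may report more compounds than this note shows. Statements on the series, on what has been measured and on what is new or still open speak of the compounds shown alone.

Within the data shown here, in a functional assay on HCT-116 cells (Homo sapiens) for cytotoxicity, read by MTT assay, with a stated time of 48 h (on this read-out higher numbers stand for weaker inhibition and lower numbers for stronger inhibition), compound 2 `CSc1ccc(C(=O)/C=C/c2ccc3c(c2)B(O)OC3)cc1` gives 10300 nM, the lower of the two numbers measured so far. Among the measured compounds shown here, the only step measured, a 1.1-fold lower number from compound 1 to compound 2 (0.05 log units; within the scatter), is within the scatter, and compound 1 `O=C(/C=C/c1ccc2c(c1)B(O)OC2)c1ccc(I)cc1` gives 11600 nM, so the two compounds cannot be ordered against each other. Compound 3 `O=C(/C=C/c1ccc2c(c1)B(O)OC2)c1ccc([N+](=O)[O-])cc1` keeps the shared core and differs from compound 2 in one place: nitro in place of methylsulfanyl on an aromatic carbon. For the measured compounds named here, the step from compound 1 to compound 2 also exchanged the group at this same place, and it moved the number by less than the scatter; no compound carries a nitro group, so nothing measured speaks for a change of any size. Compound 3 is therefore expected to sit close to compound 2, with the estimated step of a 1.0-fold lower number from compound 2 to compound 3 (0.01 log units; within the scatter) amounting to nothing beyond the scatter. The estimate for compound 3 in this assay is 10000 nM, with a range from 4000 nM to 25000 nM.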

Compound 3, half-maximal inhibitory concentration: 9100 nM
For compound 3 the middle estimate is 1.1-fold (0.04 log units) above the measured one; measured number inside the range.
By their numbers in this assay, from the lowest: compounds 3, 2 and 1 (each within the scatter of the next).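

Nitro in place of methylsulfanyl gives a 1.1-fold lower number from compound 2 to compound 3 (0.05 log units; within the scatter) in this assay and nitro in place of iodo gives a 1.3-fold lower number from compound 1 to compound 3 (0.11 log units; within the scatter) on the same read-out, so both steps stay within the scatter. On this aromatic carbon, para to a large group, the number therefore holds across three different groups, including one that brings a double bond outside aromatic rings, where the earlier pair had shown only a single exchange. No measurement on these compounds offers an explanation for this flat result. As far as these compounds go, whether the number would also hold with an amine, a carboxylic acid or a longer chain at this place remains open. The compounds shown also leave open how the number responds to a change anywhere else on the shared core.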